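The source may report more compounds than this note shows. Statements on the series, on what has been measured and on what is new or still open speak of the compounds shown alone.

In a functional assay on C6 cells (Rattus norvegicus) for cytotoxicity, read by MTT assay, with a stated time of 24 h (a higher number here means a weaker inhibitor, a lower number a stronger inhibitor), the three measured compounds give the following:

compound 1 `Cc1ccc(-c2cs/c(=N/NC(=O)CSc3nnnn3-c3ccccc3)n2-c2ccccc2)cc1`: 14.7 ug/mL
compound 2 `Cc1ccc(-c2cs/c(=N/NC(=O)CSc3ncccn3)n2-c2ccccc2)cc1`: 85 ug/mL
compound 3 `Cc1ccc(-c2cs/c(=N/NC(=O)CSc3nncn3C)n2-c2ccccc2)cc1`: 56 ug/mL

Compound 3 stands second highest of the three numbers; its nearest neighbour is compound 2, with a 1.5-fold lower number from compound 2 to compound 3 (0.18 log units; within the scatter), a step within the scatter, while compound 1 lies further off, with a 3.8-fold higher number from compound 1 to compound 3 (0.58 log units; beyond the scatter). Compound 4 `Cc1ccc(-c2cs/c(=N/NC(=O)CSc3nnc(C)s3)n2-c2ccccc2)cc1` differs from compound 3 in one place: 5-methyl-1,3,4-thiadiazol-2-yl in place of 4-methyl-4H-1,2,4-triazol-3-yl on a sulfur. Every measured step bears on this change, since each swaps the ring on that sulfur: a 5.8-fold higher number from compound 1 to compound 2 (0.76 log units; beyond the scatter), a 3.8-fold higher number from compound 1 to compound 3 (0.58 log units; beyond the scatter) and a 1.5-fold lower number from compound 2 to compound 3 (0.18 log units; within the scatter). Those swaps gave modest steps at most, and compound 4 keeps a five-membered ring with three hetero atoms, so no step beyond the scatter is expected, a 1.1-fold lower number from compound 3 to compound 4 (0.05 log units; within the scatter). Compound 4 is therefore estimated at 50 ug/mL, in the range 25 ug/mL to 100 ug/mL.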

Compound 4, half-maximal inhibitory concentration: 25.3 ug/mL
For compound 4 the middle estimate is 2.0-fold (0.30 log units) above the measured one; low and high end bracket the measured number.
By their numbers in this assay, from the lowest: compounds 1 and 4 (each within the scatter of the next); then compounds 3 and 2 (each within the scatter of the next).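

Replacing 4-methyl-4H-1,2,4-triazol-3-yl with 5-methyl-1,3,4-thiadiazol-2-yl leaves the heavy-atom, donor and acceptor counts unchanged, yet gives a 2.2-fold lower number from compound 3 to compound 4 (0.35 log units; beyond the scatter) and so shows that the ring on this sulfur matters beyond those counts. The same ring gives a 3.4-fold lower number from compound 2 to compound 4 (0.53 log units; beyond the scatter) and a 1.7-fold higher number from compound 1 to compound 4 (0.24 log units; within the scatter) and is thus the first ring here to stay within the scatter of compound 1. Nothing available explains these differences between the rings. On these data alone, whether the ring sulfur or the ring methyl carries the step remains open, as does the effect of an amine or a carboxylic acid on the ring.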